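This account rests on a few compounds, and the source may have more. Where it says the series, first, only, none or still open, it means among the compounds named here.

Compound 3 `CCOC(=O)[C@@]1(C(=O)Nc2ccccc2)C[C@H]1c1cc(OC)c(OC)c(OC)c1` gives 48700 nM in a functional assay on QGY cells (Homo sapiens) for cytotoxicity, read by MTT assay, with a stated time of 48 h (on this read-out lower numbers stand for stronger inhibition and higher numbers for weaker inhibition), the highest of the three numbers in hand; compound 1 `CCOC(=O)[C@@]1(C(=O)Nc2ccccc2Cl)C[C@H]1c1cc(OC)c(OC)c(OC)c1` gives 34300 nM and compound 2 `CCOC(=O)[C@]1(C(=O)NCc2ccc(C)cc2)C[C@H]1c1cc(OC)c(OC)c(OC)c1` gives 32100 nM, and both gaps to compound 3 lie within the scatter. Among the measured compounds shown here, the only single-place step measured so far, a 1.4-fold higher number from compound 1 to compound 3 (0.15 log units; within the scatter), is likewise within the scatter. Compound 4 `CCOC(=O)[C@@]1(C(=O)NCc2ccc(C)cc2)C[C@H]1c1cc(OC)c(OC)c(OC)c1` differs from compound 3 by 4-methylbenzyl in place of phenyl on an amide-type nitrogen. For the measured compounds named here, no measured step covers this exchange on the amide-type nitrogen; the step from compound 1 to compound 3 concerns the chloro group and does not bear on it. Going by the values given here, compound 2 carries the same 4-methylbenzyl group on the amide-type nitrogen as compound 4, although no single-place step connects the two, and its number sits within the scatter of the number for compound 3. Hence no change beyond the scatter is expected in this assay, a 1.4-fold lower number from compound 3 to compound 4 (0.13 log units; within the scatter). Compound 4 is accordingly estimated at 36000 nM, with a range from 15000 nM to 85000 nM.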

Compound 4, half-maximal inhibitory concentration: 26400 nM
Beside the measured number, compound 4's estimate is 1.4-fold (0.13 log units) above it, within the range that was stated.
By their numbers in this assay, from the lowest: compounds 4, 2, 1 and 3 (each within the scatter of the next).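

In this assay, the exchange on the amide-type nitrogen now has a direct reading, a 1.8-fold lower number from compound 3 to compound 4 (0.27 log units; within the scatter), and the comparison with the 2-chlorophenyl group reads a 1.3-fold lower number from compound 1 to compound 4 (0.11 log units; within the scatter), so 4-methylbenzyl does not separate from either aromatic group on that nitrogen. The series also gains a reading on configuration, a 1.2-fold lower number from compound 2 to compound 4 (0.08 log units; within the scatter), so the stereocentre at a saturated ring carbon does not separate this pair either: the fact that compounds 2 and 4 differ only in the configuration as drawn. Both the group on the amide-type nitrogen and this stereocentre therefore remain without a step beyond the scatter in this assay.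

Open, on these data alone, is whether a longer chain such as 2-phenylethyl, or a benzyl group carrying a carboxylic acid or an amine, on the amide-type nitrogen would give a step beyond the scatter. Equally open, as far as these compounds go, is whether the same configuration comparison would read alike with phenyl or 2-chlorophenyl on that nitrogen.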